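Methoxy added to the pendant phenyl of a chalcone series

The source may report more compounds than this note shows. Statements on the series, on what has been measured and on what is new or still open speak of the compounds shown alone.

Compound 1 `O=C(/C=C/c1cccc(O)c1)c1cccc(-n2cc(-c3ccccc3)[nH]c2=O)c1` carries a phenyl group on its shared core, and in a functional assay on PC-3 cells (Homo sapiens) for inhibition (a higher number here means a weaker inhibitor of growth, a lower number a stronger inhibitor of growth), compound 1 gives 2820 nM. Compound 2 `O=C(/C=C/c1cccc(O)c1)c1cccc(-n2cc(-c3ccc(Cl)cc3)[nH]c2=O)c1` bears a chlorinated phenyl in the same position; in this assay compound 2 gives "not determined" (no result reported), so no number is at hand for it. Compound 3 `COc1cc(/C=C/C(=O)c2cccc(-n3cc(-c4ccccc4)[nH]c3=O)c2)cc(OC)c1OC` keeps the phenyl of compound 1 and adds three methoxy groups on the cinnamoyl side; in this assay compound 3 gives 3260 nM. Of the two numbers at hand this is the higher one, yet the gap to compound 1 lies within the scatter, so the two values are not distinguished by this assay.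

Compound 4 `COc1ccc(-c2cn(-c3cccc(C(=O)/C=C/c4cc(OC)c(OC)c(OC)c4)c3)c(=O)[nH]2)cc1` is built from compound 3 by one change, (methoxy in place of hydrogen on an aromatic carbon), that is, methoxy in place of hydrogen on an aromatic carbon, para to a large group. Among the measured compounds shown here, no pair of measured compounds shows this change, so nothing measured tells how large its step is. With compound 1 and compound 3 giving values within the scatter of each other, the step from compound 3 to compound 4 is expected to be small, a 1.1-fold lower number from compound 3 to compound 4 (0.04 log units; within the scatter), in neither direction beyond the scatter. Compound 4 is therefore estimated to give 3000 nM in this assay, within a range of 1200 nM to 8000 nM.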

Compound 4, concentration for 50% growth inhibition: 6220 nM
Beside the measured number, compound 4's estimate is 2.1-fold (0.32 log units) below it; low and high end bracket the measured number.
By their numbers in this assay, from the lowest: compounds 1, 3 and 4 (each within the scatter of the next, the first and the last beyond it).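

Among the compounds shown here, the change from phenyl to 4-methoxyphenyl now has a measured size at this position in this assay, and it is the first step read there: a 1.9-fold higher number from compound 3 to compound 4 (0.28 log units; within the scatter). A methoxy para to a large group on this phenyl therefore leaves compound 4 not separated from compound 3 in this assay, and since compound 2, the other compound shown with a substituted phenyl here, has no number, this single pair is all that speaks for the position. Nothing at hand bears on why the step has this size.

The compounds shown leave open whether the same methoxy change would give a step of similar size on the core of compound 1, where the cinnamoyl side carries a hydroxyl rather than three methoxy groups. They also leave open whether a different group in the same position, such as an amine, a carboxylic acid or a longer chain, would move the number beyond the scatter in either direction.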